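Swapping a Pyrrolidine for a Bromophenyl on the Shared Core

A few compounds are considered here, and "the series" means these few. Any claim that something is new, unique, unknown or untested is made for them only; others in the source may bear on it.

Compound 1 `FC(F)(F)c1cc(NC[C@H]2CCCN2)c2cn[nH]c2c1` has been tested in an assay for inhibition of Tryptophan 2,3-dioxygenase (Homo sapiens), with stated times of 10 min and 60 min (a higher number here means a weaker inhibitor, a lower number a stronger inhibitor), where compound 1 gives 6090 nM. Of the two plain numbers in hand, compound 1 stands highest; compound 2 `O=[N+]([O-])c1ccc(CNc2cc(Br)cc3[nH]ncc23)cc1` gives 2230 nM. Compound 3 `O=[N+]([O-])c1ccc(CNc2cc(C(F)(F)F)cc3[nH]ncc23)cc1` is reported only as a limit, > 100000 nM. Within the data shown here, the single measured step, an at least 44-fold higher number from compound 2 to compound 3 (1.65 log units; beyond the scatter), is large and runs into the limit (the limit of > 100000 nM in this assay, at which 1 of the 3 values shown sits). Compound 4 `FC(F)(F)c1cc(NCc2cccc(Br)c2)c2cn[nH]c2c1` differs from compound 1 by 3-bromophenyl in place of pyrrolidin-2-yl on a saturated chain carbon bound to a nitrogen on an aromatic ring. Among the measured compounds shown here, no measured step covers this exact change, but compound 3 shows that the core shared by compound 1 and compound 4 can reach the limit. Compound 4 is expected to be weaker, a step of a 4.9-fold higher number from compound 1 to compound 4 (0.69 log units; beyond the scatter). Compound 4 is estimated at 30000 nM, between 6000 nM and 150000 nM.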

Compound 4, half-maximal inhibitory concentration: 19100 nM
For compound 4 the middle estimate is 1.6-fold (0.20 log units) above the measured one, within the range that was stated.
By their numbers in this assay, from the lowest: compound 2; then compound 1; then compound 4. At a limit, above all of these: compound 3.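

Exchanging pyrrolidin-2-yl for 3-bromophenyl on the shared core gives a 3.1-fold higher number from compound 1 to compound 4 (0.50 log units; beyond the scatter) in this assay. Compound 4 still gives a plain number, so an aromatic ring at this place does not by itself take this core to the limit, which compound 3 alone might have suggested. Nothing shown here explains the size of this step.

Still open, on these data alone, is whether the ring or its nitrogen matters more. An open-chain amine or a cyclopentyl group at this place would separate the two.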